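Swapping phenyl for cyclohexyl on the piperazine of compound 1

This account rests on a few compounds, and the source may have more. Where it says the series, first, only, none or still open, it means among the compounds named here.

Compound 1 `Nc1ccccc1NC(=O)c1ccc(CSC(=S)N2CCN(c3ccccc3)CC2)cc1` gives 87.4% in a functional assay on MGC-803 cells (Homo sapiens) for antiproliferative activity, read by CCK-8 assay, with a stated time of 72 h, tested at 8 uM (a lower number here means a weaker effect, a higher number a stronger effect of the compound at the concentration tested), the highest of the three numbers shown, though its gaps to compound 3 and to compound 2 both fall within the scatter. Compound 2 `CC1CCN(C(=S)SCc2ccc(C(=O)Nc3ccccc3N)cc2)CC1` gives 81.9%, and compound 3 `CN(Cc1cccnc1)C(=S)SCc1ccc(C(=O)Nc2ccccc2N)cc1` gives 85.5%. Within the data shown here, the only measured step, a number 3.6 percentage points higher from compound 2 to compound 3 (within the scatter), changes the group on the thiocarbonyl carbon, not the ring nitrogen altered here, so it bears only loosely on compound 4 `Nc1ccccc1NC(=O)c1ccc(CSC(=S)N2CCN(C3CCCCC3)CC2)cc1`, which differs from compound 1 by cyclohexyl in place of phenyl on an amine nitrogen in a ring. Since that step stayed within the scatter, no step beyond the scatter is expected for a number 2.4 percentage points lower from compound 1 to compound 4 (within the scatter). Compound 4 is therefore estimated at 85%, with a range from 70% to 93%.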

Compound 4, a percentage reported as inhibition, at one concentration (the size of the read-out at that concentration, not a potency): 75.3%
Compound 4: middle estimate off by 9.7 percentage points, on the high side, within the range that was stated.
By their numbers in this assay, from the lowest: compounds 4, 2, 3 and 1 (each within the scatter of the next, the first and the last beyond it).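

In this assay, among these compounds, cyclohexyl in place of phenyl on this amine nitrogen in a ring gives a number 12.1 percentage points lower from compound 1 to compound 4 (beyond the scatter), the first step here to pass the scatter. So this position responds to the change, even though the two groups have the same heavy-atom count and differ in that one ring is aromatic and the other non-aromatic. Nothing available explains the drop. From the compounds shown here alone, whether an aromatic ring is what matters here remains open, and a benzyl or 4-methoxyphenyl group on the same nitrogen could help to show it.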